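Replacing the 4-fluorobenzyl group of compound 3

This account rests on a few compounds, and the source may have more. Where it says the series, first, only, none or still open, it means among the compounds named here.

In a functional assay on DU-145 cells (Homo sapiens) for inhibition, read by trypan blue exclusion, with a stated time of 72 h (on this read-out lower numbers stand for stronger inhibition and higher numbers for weaker inhibition), compound 1 (`Cn1c(=O)c(S(=O)(=O)c2ccc(C(=O)O)cc2)cc2cnc(Nc3ccc4[nH]ccc4c3)nc21`) gives 10000 nM and compound 2 (`Cn1c(=O)c(S(=O)(=O)Cc2ccc(F)cc2F)cc2cnc(Nc3ccc4[nH]ccc4c3)nc21`) gives 1000 nM while compound 3 (`Cn1c(=O)c(S(=O)(=O)Cc2ccc(F)cc2)cc2cnc(Nc3ccc4[nH]ccc4c3)nc21`) gives 30000 nM as the highest of the three numbers. Compound 4 (`COc1ccc(S(=O)(=O)c2cc3cnc(Nc4ccc5[nH]ccc5c4)nc3n(C)c2=O)cc1`) awaits measurement. It has 4-methoxyphenyl in place of 4-fluorobenzyl on a sulfonyl sulfur. The nearest measured comparison is the modest step of a 3.0-fold higher number from compound 1 to compound 3 (0.48 log units; beyond the scatter) for 4-fluorobenzyl in place of 4-carboxyphenyl on a sulfonyl sulfur. Read backwards, it suggests that a phenyl group carried there can give a lower number than compound 3 does. The large step of a 30-fold higher number from compound 2 to compound 3 (1.48 log units; beyond the scatter) shows how far a single fluoro can move this read-out, so the uncertainty is wide. Among the measured compounds shown here, no measured compound carries 4-methoxyphenyl. A modest move toward stronger inhibition is therefore expected, with an estimated change of a 10-fold lower number from compound 3 to compound 4 (1.00 log units; beyond the scatter) in this assay as the working figure. For compound 4 the estimate is 3000 nM with an expected range of 400 nM to 20000 nM around it.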

Compound 4, half-maximal inhibitory concentration: 500 nM
Estimate against measurement, compound 4: 6.0-fold (0.78 log units) above; measured number inside the range.
By their numbers in this assay, from the lowest: compounds 4 and 2 (each within the scatter of the next); then compound 1; then compound 3.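

In this assay the group on the sulfonyl sulfur decides the outcome, and a ring of the phenyl type can bring the number down sharply (a 60-fold lower number from compound 3 to compound 4 (1.78 log units; beyond the scatter)). Compound 1 had left that unclear, but the step to compound 4 (a 20-fold lower number from compound 1 to compound 4 (1.30 log units; beyond the scatter)) shows that on the same phenyl group the swap of carboxy for methoxy alone moves the number a long way, while 4-methoxyphenyl and 2,4-difluorobenzyl cannot be told apart (a 2.0-fold lower number from compound 2 to compound 4 (0.30 log units; within the scatter)). Nothing available explains these differences.

From the compounds shown here alone, it remains open whether the gain belongs to the methoxy or to phenyl in place of benzyl, since both change at once between compound 3 and compound 4. An unsubstituted phenyl, a 4-fluorophenyl or a 4-aminophenyl on the sulfonyl sulfur would help to separate the two.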